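The source may report more compounds than this note shows. Statements on the series, on what has been measured and on what is new or still open speak of the compounds shown alone.

Working notes on the series. Compound 1 `CN(C)CCn1cnnc1-c1cc(Oc2ccc(NC(=O)N/N=C/c3c(Cl)cccc3Cl)cc2F)ccn1` in a functional assay on A549 cells (Homo sapiens) for cytotoxicity, read by MTT assay, with a stated time of 72 h (a higher number here means a weaker inhibitor, a lower number a stronger inhibitor), gives 1410 nM. Compound 2 `COc1cc(/C=N/NC(=O)Nc2ccc(Oc3ccnc(-c4nncn4CCN(C)C)c3)c(F)c2)cc(OC)c1OC` carries 3,4,5-trimethoxyphenyl in place of the 2,6-dichlorophenyl of compound 1 on the carbon with a double bond to nitrogen. In this assay compound 2 gives > 100000 nM, which is a limit of the assay and not a number. The step of an at least 70-fold higher number from compound 1 to compound 2 (1.85 log units; beyond the scatter) therefore rests on (the limit of > 100000 nM in this assay, at which 1 of the 2 values shown sits), where compound 2 stands among the values shown, with no number of its own.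

Compound 3 `CN(C)CCn1cnnc1-c1cc(Oc2ccc(NC(=O)N/N=C/c3ccc(O)c(O)c3)cc2F)ccn1` is not yet measured in this assay. It differs from compound 2 by 3,4-dihydroxyphenyl in place of 3,4,5-trimethoxyphenyl on a carbon with a double bond to nitrogen. For the measured compounds named here, the one measured step that bears on the aryl group on this carbon is an at least 70-fold higher number from compound 1 to compound 2 (1.85 log units; beyond the scatter), which shows that this group alone can move the number by a large amount; no measured step covers 3,4-dihydroxyphenyl. Because compound 2 sits at the limit (the limit of > 100000 nM in this assay, at which 1 of the 2 values shown sits), the step to compound 3 can only be guessed, and a number somewhere between the limit and compound 1 is expected, with a real chance of another limit. Compound 3 is expected to give 30000 nM, within 3000 nM to 100000 nM, meaning an expected step of an at least 3.3-fold lower number from compound 2 to compound 3 (0.52 log units; beyond the scatter).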

Compound 3, half-maximal inhibitory concentration: > 100000 nM
Compound 3 was reported as a limit; the forecaster's own chance of this, stated with the estimate: 40%; middle value at least 3.3-fold (0.52 log units) away from the limit.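

In this assay compound 3 gives > 100000 nM, which is a limit of the assay and not a number. With 3,4-dihydroxyphenyl in place of 2,6-dichlorophenyl on the carbon with a double bond to nitrogen, the result is an at least 70-fold higher number from compound 1 to compound 3 (1.85 log units; beyond the scatter), so the large step is no longer tied to 3,4,5-trimethoxyphenyl alone: a smaller group with 2 hydrogen-bond donors instead of 0 gives the same outcome, and among the three aryl groups shown only 2,6-dichlorophenyl gives a number. The step between compound 2 and compound 3 cannot be read, and the two aryl groups cannot be ranked against each other: the limit of > 100000 nM in this assay, at which 2 of the 3 values shown sit.

What the compounds shown leave open is whether the number of compound 1 depends on its two chlorine atoms or on the absence of any oxygen on the ring, a question that an unsubstituted phenyl or a 4-chlorophenyl on the same carbon would address. Also open, as far as these compounds go, is how far the number of compound 1 moves when the dimethylamino group of the shared core gives way to another amine such as morpholine.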